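Swapping chlorophenyl for isopropyl on a glycosylated acylhydrazone

This account rests on a few compounds, and the source may have more. Where it says the series, first, only, none or still open, it means among the compounds named here.

Among the measured compounds shown here, compound 1 `O=C(N/N=C/c1ccc(Cl)cc1)c1ccc(O[C@@H]2O[C@H](CO)[C@@H](O)[C@H](O)[C@H]2O)cc1` is one of three compounds measured in a functional assay on MDA-MB-231 cells (Homo sapiens) for inhibition, read by MTT assay, with a stated time of 24 h, tested at 100 uM; a higher number here means more inhibition at the concentration tested (going by the name of the read-out), a lower number less inhibition. In this assay, for the measured compounds named here, compound 1 gives 2.26%; compound 2 `CC(=O)OC[C@H]1O[C@@H](Oc2ccc(-c3nnc(C(C)C)o3)cc2)[C@H](OC(C)=O)[C@@H](OC(C)=O)[C@@H]1OC(C)=O` gives 11.9% and compound 3 `CC(=O)OC[C@H]1O[C@@H](Oc2ccc(-c3nnc(C4CCCCC4)o3)cc2)[C@H](OC(C)=O)[C@@H](OC(C)=O)[C@@H]1OC(C)=O` gives 11.6%, and both of those numbers stand within the scatter of the number for compound 1, so no measured compound separates from it. Going by the values given here, the only measured step, a number 0.3 percentage points lower from compound 2 to compound 3 (within the scatter), exchanges one alkyl group for another on an aromatic carbon and has a size within the scatter. Compound 4 `CC(C)/C=N/NC(=O)c1ccc(O[C@@H]2O[C@H](CO)[C@@H](O)[C@H](O)[C@H]2O)cc1` differs from compound 1 in one place: isopropyl in place of 4-chlorophenyl on a carbon with a double bond to nitrogen. Among the compounds with values here, no measured pair shares this change; the step between compound 2 and compound 3 is the nearest comparison, an alkyl-for-alkyl exchange on a different core, and it moved the read-out only within the scatter. Within the data shown here, since every measured number is low and the one step is small, compound 4 is expected to stay near compound 1, and the step of a number 0.7 percentage points higher from compound 1 to compound 4 (within the scatter) is estimated to lie within the scatter. Compound 4 is therefore estimated at 3%, with a range from 0% to 12%.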

Compound 4, a percentage reported as inhibition, at one concentration (the size of the read-out at that concentration, not a potency): 1.7%
Estimate against measurement, compound 4: 1.3 percentage points above, and the stated range covers the measured number.
By their numbers in this assay, from the lowest: compounds 4, 1, 3 and 2 (each within the scatter of the next, the first and the last beyond it).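

On the carbon with a double bond to nitrogen, exchanging 4-chlorophenyl for isopropyl takes away an aromatic ring and the chlorine, and in this assay the result is a number 0.6 percentage points lower from compound 1 to compound 4 (within the scatter). Among the compounds shown here, this gives the first measured reading at this position on the shared core, and it shows that this read-out at the single concentration tested does not tell the aryl group from the smaller alkyl group. Nothing available explains this result. The compounds shown leave open whether an amine or a carboxylic acid at this place, or either one carried on a longer chain, would separate from compound 1. On these data alone, it also remains open whether acetate esters on the sugar hydroxyl groups of compound 4 would change its reading.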